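Lengthening the Aryl Chain of Compound 1

The source may report more compounds than this note shows. Statements on the series, on what has been measured and on what is new or still open speak of the compounds shown alone.

Compound 1 `Cc1ccc(C#Cc2cc3cn([C@H]4C[C@H](O)[C@@H](CO)O4)c(=O)nc3o2)cc1` was examined in an ADME assay on HEL cells (Homo sapiens) for cytotoxicity, with a stated time of 3 days; on this read-out higher numbers stand for lower toxicity in this test and lower numbers for higher toxicity in this test. In this test compound 1 reaches >= 510000 nM, which is a limit of the assay rather than a measured number. Compound 2 `Cc1ccc(CCc2cc3cn([C@H]4C[C@H](O)[C@@H](CO)O4)c(=O)nc3o2)cc1` carries 2-(4-methylphenyl)ethyl in place of 2-(4-methylphenyl)ethynyl on an aromatic carbon, and in this assay compound 2 gives 540000 nM. The step that the limit leaves unreadable from compound 1 to compound 2 cannot be given a size, since the limit of >= 510000 nM in this assay, at which 1 of the 2 values shown sits, hides where compound 1 truly sits.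

Compound 3 `CCCCCc1ccc(C#Cc2cc3cn([C@H]4C[C@H](O)[C@@H](CO)O4)c(=O)nc3o2)cc1` differs from compound 1 by butyl in place of hydrogen on a saturated chain carbon bound to an aromatic carbon. No measured step touches this change, and the only step shown is itself unreadable, so nothing seen here points to a move in either direction beyond the usual scatter. Compound 3 is therefore expected to give about 400000 nM in this assay, within a range of 100000 nM to 600000 nM. The expected step from compound 1 is an at least 1.2-fold lower number from compound 1 to compound 3 (0.10 log units; that floor lies within the scatter), and a limit is as likely as a number.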

Compound 3, minimum cytotoxic concentration: 470000 nM
Compound 3: the middle estimate sits 1.2-fold (0.07 log units) below what was measured, within the range that was stated.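

Butyl in place of hydrogen on a saturated chain carbon bound to an aromatic carbon, which turns methyl into pentyl, gives in this assay an at least 1.0-fold lower number from compound 1 to compound 3 (0.03 log units; that floor lies within the scatter). Unlike the earlier step, which cannot be read, this one has a readable floor, and it gives the first look at a longer chain at this place. The floor shows no change beyond the usual scatter, but the true step could be larger because compound 1 has only a limit, not a measured number: the limit of >= 510000 nM in this assay, at which 1 of the 3 values shown sits.

As far as these compounds go, whether an octyl chain, an amine or a carboxylic acid at this same place would leave the number at this level remains open. The compounds shown also cannot tell whether a chain of another length would give a step clearly beyond the scatter.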